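The source may hold more compounds than are shown below. What is called first, only, known or untested is meant among the compounds shown, and "the series" means these compounds.

Among the compounds with values here, the two compounds measured so far share a core and differ in the group hanging from the ring that sits on the benzene. Compound 1 `O=C(NC[C@H]1CN(c2ccc(-n3cccc3CN3CCCCC3)cc2)C(=O)O1)c1ccc(Cl)s1` and compound 2 `CCNCc1csc(-c2ccc(N3C[C@H](CNC(=O)c4ccc(Cl)s4)OC3=O)cc2)n1` were both tested in an assay on isolated protein (plasma) for inhibition of coagulation factor X (Oryctolagus cuniculus); a higher number here means a weaker inhibitor, a lower number a stronger inhibitor. In this assay compound 1 gives 3230 nM. Compound 2 gives 1160 nM, the lowest of the two numbers, and compound 1 stands a good deal higher, a gap beyond the usual scatter. Compound 3 `CC1CCN(Cc2csc(-c3ccc(N4C[C@H](CNC(=O)c5ccc(Cl)s5)OC4=O)cc3)n2)CC1` has not yet been measured. It differs from compound 2 in one place: 4-methylpiperidin-1-yl in place of ethylamino on a saturated chain carbon bound to an aromatic carbon. A secondary amine with a short chain is exchanged for a ring-closed tertiary amine carrying a methyl group. Within the data shown here, no measured pair shows exactly this change, so the size of the step is open. A modest move toward weaker inhibition is expected, roughly a 1.6-fold higher number from compound 2 to compound 3 (0.19 log units; within the scatter), though the step may well stay within the scatter. For compound 3 the estimate in this assay is 1800 nM, with a plausible range from 700 nM to 4500 nM.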

Compound 3, half-maximal inhibitory concentration: 4020 nM
Compound 3: middle estimate off by 2.2-fold (0.35 log units), on the low side, within the range that was stated.
By their numbers in this assay, from the lowest: compound 2; then compounds 1 and 3 (each within the scatter of the next).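

In this assay, putting 4-methylpiperidin-1-yl in place of ethylamino on this saturated chain carbon gives a 3.5-fold higher number from compound 2 to compound 3 (0.54 log units; beyond the scatter), so the group at this position can change the reading by more than the scatter. The change does several things at once: the hydrogen-bond donor count falls from 1 to 0, a six-membered ring appears, and the group grows from 3 to 7 heavy atoms, and this single step cannot separate these differences. Nothing available here gives a reason for the step.

Still open, going by these compounds, is which of these differences matters: plain piperidin-1-yl, without the methyl, and dimethylamino, a tertiary amine with no ring, would help to pull them apart. On these data alone, it is also open whether a smaller secondary amine, such as methylamino, or a primary amine would give a lower number than compound 2.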